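A sulfonamide aryl swap close to the assay limit

The source may report more compounds than this note shows. Statements on the series, on what has been measured and on what is new or still open speak of the compounds shown alone.

In a functional assay on cells (leukaemia cell line, Homo sapiens) for inhibition, read by sulforhodamine B assay, with a stated time of 48 h (a lower number here means a stronger inhibitor of growth, a higher number a weaker inhibitor of growth), compound 1 (`O=S(=O)(Nc1ccc(F)c(Cl)c1)c1ccc(-c2cnc(C3CC3)o2)cc1`) gives 73700 nM, and compound 3 (`Cc1ccc(Cl)c(NS(=O)(=O)c2ccc(-c3cnc(C4CC4)o3)cc2)c1`) gives 52800 nM, so these two numbers stand within the scatter of each other. Compound 2 (`O=S(=O)(Nc1cc(Cl)ccc1Cl)c1ccc(-c2cnc(C3CC3)o2)cc1`) returns only a limit of the assay, > 100000 nM. Compound 4 (`O=S(=O)(Nc1ccc(I)c(Cl)c1)c1ccc(-c2cnc(C3CC3)o2)cc1`) carries 3-chloro-4-iodophenyl in place of 2-chloro-5-methylphenyl on a sulfonamide nitrogen. Three measured exchanges bear on this change: a 1.4-fold lower number from compound 1 to compound 3 (0.14 log units; within the scatter), an at least 1.3-fold higher number from compound 1 to compound 2 (0.13 log units; that floor lies within the scatter) and an at least 1.8-fold lower number from compound 2 to compound 3 (0.27 log units; that floor lies within the scatter). None of them exceeds the scatter, so no step beyond it is expected in this assay. The expected change is a 1.1-fold higher number from compound 3 to compound 4 (0.06 log units; within the scatter). Compound 4 is estimated at 60000 nM, with an expected range of 25000 nM to 100000 nM.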

Compound 4, concentration for total growth inhibition: 19600 nM
The estimate for compound 4 lay 3.1-fold (0.49 log units) above the measured number; measured number below the stated range.
By their numbers in this assay, from the lowest: compound 4; then compounds 3 and 1 (each within the scatter of the next). At a limit, above all of these: compound 2.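

In this assay, a change of the aryl group on the sulfonamide nitrogen now gives a step beyond the scatter, which no earlier exchange did: a 2.7-fold lower number from compound 3 to compound 4 (0.43 log units; beyond the scatter). Iodo in place of fluoro on an aromatic carbon, a single-atom change, is enough for a 3.8-fold lower number from compound 1 to compound 4 (0.58 log units; beyond the scatter). Compound 2 stands at a limit, so an at least 5.1-fold lower number from compound 2 to compound 4 (0.70 log units; beyond the scatter) is only a floor: the limit of > 100000 nM in this assay, at which 1 of the 4 values shown sits.

On these data alone, whether bromo, methoxy or an amine in place of iodo would give a similar step stays open. So does whether the chloro of 3-chloro-4-iodophenyl contributes to this step at all.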